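The compounds below may be only part of what the source reports. "The series", "measured", "known", "first", "only" and "open" are said of these compounds alone.

Measured compounds:
- compound 1 `COc1ccc(NC(=O)Nc2cccc(CNc3ncnc4ccccc34)c2)cc1`: in a functional assay on MGC-803 cells (Homo sapiens) for antiproliferative activity, read by MTT assay (on this read-out higher numbers stand for weaker inhibition and lower numbers for stronger inhibition), compound 1 gives 27300 nM
- compound 2 `O=C(Nc1cccc(CNc2ncnc3ccccc23)c1)Nc1ccccc1Cl`: in this assay compound 2 gives only a limit, > 50000 nM

Within the data shown here, compound 1 holds the only numeric value in this set; the other entry is a limit. The step from compound 1 to compound 2 is an at least 1.8-fold higher number from compound 1 to compound 2 (0.26 log units; that floor lies within the scatter), the change being 2-chlorophenyl in place of 4-methoxyphenyl on an amide-type nitrogen, and it ends at the limit (the limit of > 50000 nM in this assay, at which 1 of the 2 values shown sits). Compound 3 `O=C(Nc1cccc(CNc2ncnc3ccccc23)c1)Nc1cccc(C(F)(F)F)c1` is not yet measured; it differs from compound 1 as 3-(trifluoromethyl)phenyl in place of 4-methoxyphenyl on an amide-type nitrogen. Among the measured compounds shown here, only the step to compound 2 bears on this change, a swap of the same 4-methoxyphenyl for another substituted phenyl on the same nitrogen, and that step ran toward a weaker number with its floor inside the scatter. For compound 3 a step of similar size in the same direction is expected, a 1.6-fold higher number from compound 1 to compound 3 (0.22 log units; within the scatter), with a real chance that only a limit is returned. Compound 3 is therefore estimated at 45000 nM, range 15000 nM to 130000 nM.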

Compound 3, half-maximal inhibitory concentration: > 50000 nM
Compound 3 gave a limit, no number (the forecaster's own chance of this, stated with the estimate: 45%); middle value at least 1.1-fold (0.04 log units) from the limit.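

In this assay, 3-(trifluoromethyl)phenyl in place of 4-methoxyphenyl on the amide-type nitrogen gives an at least 1.8-fold higher number from compound 1 to compound 3 (0.26 log units; that floor lies within the scatter); compound 3 returns only a limit, so this step is a floor and not a measured size. The step between compound 2 and compound 3 cannot be read, as both are limits, and their two substituted phenyl groups cannot be ranked. A second substituted phenyl group now ends at the same limit, so this outcome at this position is not confined to 2-chlorophenyl, and compound 1 remains the only compound with a number: the limit of > 50000 nM in this assay, at which 2 of the 3 values shown sit.

How far compound 2 and compound 3 truly lie from compound 1 stays open, and the floor shown here lies within the scatter. Also open, on these data alone, is what an unsubstituted phenyl, or a phenyl carrying an amine or a carboxylic acid, would return on this nitrogen.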